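The source may hold more compounds than are shown below. What is called first, only, known or untested is meant among the compounds shown, and "the series" means these compounds.

Compound 1 `COc1cc(-c2nn(-c3cccc(NC(=O)Nc4ccc(Cl)c(Cl)c4)c3)cc2-c2ccncc2)ccc1Cl` carries a (3,4-dichlorophenyl)amino on the carbonyl carbon; in a functional assay on UACC-257 cells (Homo sapiens) for inhibition, read by sulforhodamine B assay, with a stated time of 48 h (on this read-out higher numbers stand for weaker inhibition of growth and lower numbers for stronger inhibition of growth), compound 1 gives 3110 nM. Compound 2 `COc1cc(-c2nn(-c3cccc(NC(=O)c4ccc(Cl)c(C(F)(F)F)c4)c3)cc2-c2ccncc2)ccc1Cl` replaces that group with 4-chloro-3-(trifluoromethyl)phenyl, so the urea becomes an amide. In this assay compound 2 gives only the limit > 32500 nM, a limit and not a number. The measured step is an at least 10-fold higher number from compound 1 to compound 2 (1.01 log units; beyond the scatter); on the numbers shown compound 2 stands at the weak end of the pair, at the limit of > 32500 nM in this assay, at which 1 of the 2 values shown sits.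

Compound 3 `COc1cc(-c2nn(-c3cccc(NC(=O)Nc4ccc(Cl)c(C(F)(F)F)c4)c3)cc2-c2ccncc2)ccc1Cl` differs from compound 2 by (4-chloro-3-(trifluoromethyl)phenyl)amino in place of 4-chloro-3-(trifluoromethyl)phenyl on a carbonyl carbon, restoring the urea while keeping the aryl ring of compound 2. For the measured compounds named here, the only step that bears on it is the one from compound 1 to compound 2, which ran the other way and was large; a step of similar size in the opposite direction, toward stronger inhibition, is therefore expected in this assay, namely an at least 13-fold lower number from compound 2 to compound 3 (1.11 log units; beyond the scatter). Compound 3 is estimated at 2500 nM, within 800 nM to 8000 nM.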

Compound 3, concentration for total growth inhibition: 6030 nM
For compound 3 the middle estimate is 2.4-fold (0.38 log units) below the measured one, within the range that was stated.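

Restoring the amino group on the carbonyl carbon while the 4-chloro-3-(trifluoromethyl)phenyl ring stays unchanged gives an at least 5.3-fold lower number from compound 2 to compound 3 (0.73 log units; beyond the scatter) in this assay, so in this pair the loss of growth inhibition goes with the amide and not with that ring. With the urea present, trifluoromethyl in place of chloro on an aromatic carbon gives a 1.9-fold higher number from compound 1 to compound 3 (0.29 log units; within the scatter), so in this assay this change does not separate the two ureas. The amide end of the first step is a limit and not a number: the limit of > 32500 nM in this assay, at which 1 of the 3 values shown sits.

On these data alone, whether the urea nitrogen can give way to an oxygen, as in a carbamate, or to a methylene while growth inhibition is kept remains open. Also open, as far as these compounds go, is how a methyl or a methoxy would compare with chloro and trifluoromethyl on the urea's aryl ring.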